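The source may report more compounds than this note shows. Statements on the series, on what has been measured and on what is new or still open speak of the compounds shown alone.

Compound 1 `CN(C)CCn1c(N)c(-c2nc3ccccc3[nH]2)c2nc(C#N)c(C#N)nc21`: > 50000 nM
Compound 2 `CN(C)CCCn1c(N)c(-c2nc3ccccc3[nH]2)c2nc(C#N)c(C#N)nc21`: 10400 nM

Both compounds were tested in a functional assay on A549 cells (Homo sapiens) for antiproliferative activity, read by MTT assay, with a stated time of 48 h; on this read-out lower numbers stand for stronger inhibition and higher numbers for weaker inhibition. The entry for compound 1 is a limit of the assay, not a number. For the measured compounds named here, compound 2, at 10400 nM, therefore holds the only true number so far.

Compound 3 `CCN(CC)CCCn1c(N)c(-c2nc3ccccc3[nH]2)c2nc(C#N)c(C#N)nc21` carries diethylamino in place of dimethylamino on a saturated chain carbon, three bonds along the chain from an aromatic nitrogen.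

Going by the values given here, only one measured step is available: an at least 4.8-fold lower number from compound 1 to compound 2 (0.68 log units; beyond the scatter). It came with (dimethylamino)methyl in place of dimethylamino, a change in the chain rather than in the groups on the chain's nitrogen, so it offers only a loose guide here. Among the compounds with values here, no measured step covers the new change. The step expected in this assay is a 1.2-fold lower number from compound 2 to compound 3 (0.06 log units; within the scatter), which would not lie beyond the scatter. For compound 3 the estimated value is 9000 nM, with an expected range of 3000 nM to 27000 nM.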

Compound 3, half-maximal inhibitory concentration: 25300 nM
Estimate against measurement, compound 3: 2.8-fold (0.45 log units) below; the measured number falls inside the stated range.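

Compounds 1 and 2 differed in the chain, whereas this result shows that the groups on the chain's nitrogen also affect the read-out: going from 3-(dimethylamino)propyl to 3-(diethylamino)propyl in this assay gives a 2.4-fold higher number from compound 2 to compound 3 (0.39 log units; beyond the scatter). Here the smaller dimethylamino group is the better of the two on this chain, so adding carbon atoms to that nitrogen does not help. The comparison across the change in both chain and nitrogen groups gives an at least 1.9-fold lower number from compound 1 to compound 3 (0.29 log units; that floor lies within the scatter), so it shows no clear gain. Compound 1 is recorded only as a limit of the assay, so that comparison gives only a floor: the limit of > 50000 nM in this assay, at which 1 of the 3 values shown sits.

Still open, from the compounds shown here alone, is how a ring amine such as piperidine or morpholine would read in the same place. A longer chain, such as a 4-(dimethylamino)butyl group, also remains to be placed against these results.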